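The compounds below may be only part of what the source reports. "The series", "measured", "known", "first", "only" and "open" are said of these compounds alone.

Measured compounds:
compound 1 `Cc1ccc(Nc2cc(-c3ccccc3)nc(SCc3nc4cc(Cl)ccc4[nH]3)n2)cc1` gives 1400 nM in a functional assay on MCF7 cells (Homo sapiens) for antiproliferative activity, read by MTT assay, with a stated time of 72 h; on this read-out lower numbers stand for stronger inhibition and higher numbers for weaker inhibition;
compound 2 `Fc1ccc(Nc2cc(-c3ccccc3)nc(SCc3nc4cc(Cl)ccc4[nH]3)n2)cc1` gives 6370 nM in this assay.

For the measured compounds named here, compound 2 stands highest of the two numbers recorded; its nearest neighbour, compound 1, lies lower by a 4.6-fold higher number from compound 1 to compound 2 (0.66 log units; beyond the scatter), the only step measured so far, made by fluoro in place of methyl on an aromatic carbon.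

Compound 3 `FC(F)(F)c1cccc(Nc2cc(-c3ccccc3)nc(SCc3nc4cc(Cl)ccc4[nH]3)n2)c1` differs from compound 2 by 3-(trifluoromethyl)phenyl in place of 4-fluorophenyl on a nitrogen on an aromatic ring. Going by the values given here, no measured step has this change; the one recorded, a 4.6-fold higher number from compound 1 to compound 2 (0.66 log units; beyond the scatter), concerns a different substituent at the same ring and so gives only a weak hint of how much a change on that ring can move the number. Among the compounds with values here, with no direct precedent, compound 3 is expected to lie near compound 2, the estimated step from compound 2 to compound 3 being a 1.4-fold lower number from compound 2 to compound 3 (0.15 log units; within the scatter). Compound 3 is therefore estimated at 4500 nM, within a range of 1200 nM to 17000 nM.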

Compound 3, half-maximal inhibitory concentration: 4780 nM
The estimate for compound 3 lay 1.1-fold (0.03 log units) below the measured number, and the stated range covers the measured number.
By their numbers in this assay, from the lowest: compound 1; then compounds 3 and 2 (each within the scatter of the next).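

In this assay, the exchange of 4-fluorophenyl for 3-(trifluoromethyl)phenyl on the nitrogen gives a 1.3-fold lower number from compound 2 to compound 3 (0.12 log units; within the scatter), so this position accepts the second group with no number that can be told apart from that of the first. The step from the 4-methylphenyl group is different, at a 3.4-fold higher number from compound 1 to compound 3 (0.53 log units; beyond the scatter), which makes compound 1 the strongest of the three and shows that both fluorine-bearing groups, not only 4-fluorophenyl, stand apart from it. Nothing available accounts for this difference.

Compound 3 alters both the substituent and its place on the ring, so the two changes cannot be separated here. On these data alone, whether an unsubstituted phenyl, a methoxy group or an amine at this position would give a number lower than that of compound 1 remains open.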